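This account rests on a few compounds, and the source may have more. Where it says the series, first, only, none or still open, it means among the compounds named here.

Measured in a functional assay on the whole organism (Hindlimb, strain CF-1) with Mus musculus as the target, in the maximal electroshock model, with a stated time of 1 h; a higher number here means that more compound is needed for the effect, a lower number that less compound is needed:

Compound 1 `NS(=O)(=O)NC[C@H]1COc2ccccc2O1`: 199 mg/kg
Compound 2 `NS(=O)(=O)NC[C@H]1COc2ccc(Cl)cc2O1`: 104 mg/kg

With only these two numbers available, compound 1 has no clear rank, as it stands within the usual scatter of compound 2. Among the compounds with values here, the single measured step is a 1.9-fold lower number from compound 1 to compound 2 (0.28 log units; within the scatter), and it comes from chloro in place of hydrogen on an aromatic carbon.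

Compound 3 `NS(=O)(=O)NC[C@H]1COc2cc(F)ccc2O1` keeps the core of compound 1 and carries one change: fluoro in place of hydrogen on an aromatic carbon. In words, this is fluoro in place of hydrogen on an aromatic carbon. Within the data shown here, the chloro step is the only measured one that bears on this change, and it is an imperfect guide, since it involves a different group and no fluoro compound has been measured yet. Since the measured step, a 1.9-fold lower number from compound 1 to compound 2 (0.28 log units; within the scatter), stays within the scatter, no step beyond the scatter is expected in this assay, and no firm direction can be assigned. The estimated step is a 1.3-fold lower number from compound 1 to compound 3 (0.12 log units; within the scatter). The expected value for compound 3 is 150 mg/kg, with an estimated range of 70 mg/kg to 300 mg/kg.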

Compound 3, dose for half-maximal effect: 161 mg/kg
Estimate against measurement, compound 3: 1.1-fold (0.03 log units) below; measured number inside the range.
By their numbers in this assay, from the lowest: compounds 2, 3 and 1 (each within the scatter of the next).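

In this assay the replacement of hydrogen by fluoro, on an aromatic carbon meta to a fused ring and para to a fused ring, gives a 1.2-fold lower number from compound 1 to compound 3 (0.09 log units; within the scatter) and so leaves compound 3 indistinguishable from compound 1. Compound 3 is the only fluoro compound shown, so this change now has a direct reading of its own, where previously the chloro compound was the only guide. The chloro change, with a 1.9-fold lower number from compound 1 to compound 2 (0.28 log units; within the scatter) at a different aromatic carbon, is also within the scatter, so neither of the two halogen changes shown yet separates a compound from compound 1 in this assay. No available evidence accounts for this result.

Going by these compounds, it remains open whether chloro at the carbon carrying fluoro in compound 3, or fluoro at the carbon carrying chloro in compound 2, would give a similar reading. It is also unknown whether a different group at this position, such as methoxy, an amine or a carboxylic acid, would produce a step beyond the scatter.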